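The source may hold more compounds than are shown below. What is called first, only, known or untested is meant among the compounds shown, and "the series" means these compounds.

Measured so far in a functional assay on A498 cells (Homo sapiens) for inhibition, read by sulforhodamine B assay, with a stated time of 48 h; a lower number here means a stronger inhibitor of growth, a higher number a weaker inhibitor of growth:
compound 1, `COc1cc(C)cc(-c2nn(CC#N)cc2-c2ccc(-c3cccc(C(C)=O)c3)nc2)c1`, gives 5140 nM
compound 2, `Cc1cc(O)cc(-c2nn(CC#N)cc2-c2ccnc(-c3ccc(Oc4ccccc4)cc3)c2)c1`, gives 16700 nM
compound 3, `COc1cc(C)cc(-c2nn(CC#N)cc2-c2ccnc(-c3ccc(N(C)C)cc3)c2)c1`, gives 818 nM

Compound 3 holds the lowest number of the three in this assay. Its nearest neighbour is compound 1, whose value sits beyond the scatter above it; compound 2 lies further away still, also beyond the scatter. Compound 2 differs from compound 3 in two places at once, so the pair shows only its combined outcome and nothing about either change on its own.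

Compound 4 is `Cc1cc(O)cc(-c2nn(CC#N)cc2-c2ccnc(-c3ccc(N(C)C)cc3)c2)c1`. It is compound 3 with hydrogen in place of methyl on an oxygen on an aromatic ring. Within the data shown here, no measured pair in this set isolates that single change; compound 2 carries the same hydroxy group but differs from compound 3 in a second place as well, so its gap to compound 3 cannot be divided. With nothing direct to go on, the expectation is a step of modest size, leaning toward a higher number, and possibly none beyond the scatter. For compound 4 the expected value in this assay is 1500 nM, within a range of 400 nM to 6000 nM, which corresponds to an estimated step of a 1.8-fold higher number from compound 3 to compound 4 (0.26 log units; within the scatter).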

Compound 4, concentration for total growth inhibition: 13400 nM
For compound 4 the middle estimate is 8.9-fold (0.95 log units) below the measured one, and the stated range ends below it.
By their numbers in this assay, from the lowest: compound 3; then compound 1; then compounds 4 and 2 (each within the scatter of the next).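

In this assay, among these compounds, methoxy to hydroxy on the 3-methoxy-5-methylphenyl group, with the dimethylamino group held constant, is the first isolated reading of this change; it gives a 16-fold higher number from compound 3 to compound 4 (1.21 log units; beyond the scatter), so the methyl on this oxygen on an aromatic ring has a large bearing on the number. With the hydroxy group held constant, dimethylamino in place of phenoxy on an aromatic carbon gives a 1.2-fold lower number from compound 2 to compound 4 (0.10 log units; within the scatter), which allows the earlier two-place gap to be divided: in these compounds the change on the oxygen carries the difference, while the exchange of dimethylamino and phenoxy does not separate compounds 2 and 4. Nothing at hand gives a measured reason for the large step at the oxygen.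

From the compounds shown here alone, how far the oxygen substituent can depart from methyl stays open, and an ethyl ether, a longer chain or an amine in place of the oxygen would each address that. Also open, going by these compounds, is whether the methoxy to hydroxy step repeats at a similar size with phenoxy in place of dimethylamino, or on the core of compound 1.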